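A few compounds are considered here, and "the series" means these few. Any claim that something is new, unique, unknown or untested is made for them only; others in the source may bear on it.

Working notes on the series. Compound 1 `COc1cc2c(Oc3ccc(NC(=O)c4nn(-c5ccccc5)c(=O)cc4C)cc3F)ccnc2cc1OCCCN1CCCC1` is the weaker of the two measured compounds on the numbers shown, giving in a functional assay on NCI-H460 cells (Homo sapiens) for inhibition, read by MTT assay, with a stated time of 72 h (on this read-out lower numbers stand for stronger inhibition and higher numbers for weaker inhibition), a value of 460 nM. Among the measured compounds shown here, compound 2 `COc1cc2c(Oc3ccc(NC(=O)c4nn(-c5ccccc5)c(=O)cc4C)cc3F)ccnc2cc1OCCCN1CCN(C)CC1` gives in this assay a value of 360 nM; the single measured step, a 1.3-fold lower number from compound 1 to compound 2 (0.11 log units; within the scatter), concerns the amine on the saturated chain and is within the scatter. Compound 3 `COc1cc2c(Oc3ccc(NC(=O)c4nn(-c5cccc(F)c5)c(=O)cc4C)cc3F)ccnc2cc1OCCCN1CCCC1` differs from compound 1 by fluoro in place of hydrogen on an aromatic carbon, at the aromatic ring attached to the shared core rather than on the chain. For the measured compounds named here, no measured step touches this position, so nothing in the data sets a direction for it. Going by the values given here, the one measured step lies within the scatter, which gives no grounds for expecting a change beyond it here either. The step from compound 1 to compound 3 is therefore expected to be a 1.2-fold lower number from compound 1 to compound 3 (0.06 log units; within the scatter). Compound 3 is estimated at 400 nM in this assay, with a range of 180 nM to 900 nM.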

Compound 3, half-maximal inhibitory concentration: 280 nM
Compound 3: the middle estimate sits 1.4-fold (0.15 log units) above what was measured, and the stated range covers the measured number.
By their numbers in this assay, from the lowest: compounds 3, 2 and 1 (each within the scatter of the next).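

Among the compounds shown here, the first measured step at this position, phenyl to 3-fluorophenyl on the shared core, gives in this assay a 1.6-fold lower number from compound 1 to compound 3 (0.22 log units; within the scatter). A single fluoro on this aromatic carbon therefore keeps the number within the scatter of the parent, so this position, like the amine on the chain, has so far shown no change that can be read as real. Nothing at hand bears on the reason for this result.

From the compounds shown here alone, what a larger group such as chloro, methoxy or nitrile would do on the same aromatic carbon stays open, as one small atom says little about the wider tolerance of this ring. Also open, going by these compounds, is whether fluoro on this ring and 4-methylpiperazin-1-yl on the chain would together give a step beyond the scatter.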